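From 2-methoxyphenyl to 2,4-dichlorophenyl on a shared core

A few compounds are considered here, and "the series" means these few. Any claim that something is new, unique, unknown or untested is made for them only; others in the source may bear on it.

Going by the values given here, in a functional assay on HT-1080 cells (Homo sapiens) for cytotoxicity, read by MTT assay, with a stated time of 72 h (on this read-out lower numbers stand for stronger inhibition and higher numbers for weaker inhibition), compound 1 (`COc1ccc(/C=C2\CCC/C(=C\c3cccc(OC)c3OC)C2=O)cc1OC`) gives 6400 nM while compound 2 (`COc1ccccc1/C=C1\CCC/C(=C\c2ccc(OC)c(OC)c2)C1=O`) gives 8100 nM and so stands within the scatter of the only other measured number. Compound 3 (`COc1ccc(/C=C2\CCC/C(=C\c3ccc(Cl)cc3Cl)C2=O)cc1OC`) is not yet measured. It differs from compound 2 by 2,4-dichlorophenyl in place of 2-methoxyphenyl on a double-bonded chain carbon bound to a double-bonded ring carbon. Among the compounds with values here, the one measured step that bears on this is indirect: hydrogen in place of methoxy on an aromatic carbon of that same group gave a 1.3-fold higher number from compound 1 to compound 2 (0.10 log units; within the scatter) and stayed within the scatter. Within the data shown here, no measured compound carries chlorine, so the data leave the new step open. With only a 1.3-fold higher number from compound 1 to compound 2 (0.10 log units; within the scatter) as a guide, no step beyond the scatter is expected in this assay here. The estimated step runs a 1.4-fold lower number from compound 2 to compound 3 (0.13 log units; within the scatter) as an expectation only. Compound 3 is expected at 6000 nM (estimated range 2000 nM to 16000 nM).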

Compound 3, half-maximal inhibitory concentration: 10500 nM
Compound 3: the middle estimate sits 1.8-fold (0.24 log units) below what was measured; low and high end bracket the measured number.
By their numbers in this assay, from the lowest: compounds 1, 2 and 3 (each within the scatter of the next).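

In this assay, the move from 2-methoxyphenyl to 2,4-dichlorophenyl on a double-bonded chain carbon bound to a double-bonded ring carbon gives a 1.3-fold higher number from compound 2 to compound 3 (0.11 log units; within the scatter) and so stays within the scatter. The earlier step at this group only removed a methoxy group from the aromatic ring, whereas this one replaces the whole substituted ring. The oxygen-bearing group with a hydrogen-bond acceptor gives way to a chlorine-bearing group with none, and the read-out shows no step beyond the scatter. No measurement shown here accounts for this result.

Going by these compounds, whether an amine or a carboxylic acid on the aromatic ring at this place would move the number beyond the scatter remains open. So does the question of whether 4-chlorophenyl or 2-chlorophenyl alone would read like 2,4-dichlorophenyl on the shared core.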